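The source may report more compounds than this note shows. Statements on the series, on what has been measured and on what is new or still open speak of the compounds shown alone.

Two compounds share one core and differ only in the group attached to a saturated chain carbon bound to an aromatic nitrogen. Compound 1 `COc1ccc(Cn2cc(CNC(=O)c3cn(-c4ccccc4)nc3-c3ccc(OC)cc3)nn2)cc1` carries 4-methoxyphenyl there, and in a functional assay on MIA PaCa-2 cells (Homo sapiens) for antiproliferative activity, read by sulforhodamine B assay, with a stated time of 48 h (on this read-out lower numbers stand for stronger inhibition of growth and higher numbers for weaker inhibition of growth), compound 1 gives 2500 nM. Compound 2 `COc1ccc(-c2nn(-c3ccccc3)cc2C(=O)NCc2cn(Cc3cc(OC)cc(OC)c3)nn2)cc1` carries 3,5-dimethoxyphenyl instead, and in this assay compound 2 gives 5800 nM, the higher of the two numbers. The step of a 2.3-fold higher number from compound 1 to compound 2 (0.37 log units; beyond the scatter) shows that adding a second methoxy and moving both weakened growth inhibition modestly. Compound 3 `COc1ccc(-c2nn(-c3ccccc3)cc2C(=O)NCc2cn(Cc3cc(OC)c(OC)c(OC)c3)nn2)cc1` goes one step further: methoxy in place of hydrogen on an aromatic carbon, so the ring becomes 3,4,5-trimethoxyphenyl. Within the data shown here, only the single step from compound 1 to compound 2 bears on this change, and it was modest. A further small loss, or no change beyond the scatter, is therefore expected, a step of about a 1.3-fold higher number from compound 2 to compound 3 (0.11 log units; within the scatter). Compound 3 is thus estimated at 7500 nM in this assay, within a range of 2500 nM to 22000 nM.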

Compound 3, concentration for 50% growth inhibition: 31600 nM
Estimate against measurement, compound 3: 4.2-fold (0.62 log units) below; measured number outside the range, above it.
By their numbers in this assay, from the lowest: compound 1; then compound 2; then compound 3.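

Putting a methoxy on the aromatic carbon para to a large group, ortho to two methoxy groups, does not leave growth inhibition in this assay where it was: it gives a 5.4-fold higher number from compound 2 to compound 3 (0.74 log units; beyond the scatter). Taken across the series, the full change from 4-methoxyphenyl to 3,4,5-trimethoxyphenyl gives a 13-fold higher number from compound 1 to compound 3 (1.10 log units; beyond the scatter), so among these three compounds the number rises at each step as the ring gains methoxy groups, and no compound goes against that order. Nothing available explains why this added methoxy weakens growth inhibition.

The compounds shown cannot separate the number of methoxy groups from where they sit on the ring. From the compounds shown here alone, how a plain phenyl, or a ring carrying a hydroxy group or an amine instead of methoxy, would behave on the same core also remains open.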